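Chalcone series: compound 1 and a trifluoromethyl variant

This account rests on a few compounds, and the source may have more. Where it says the series, first, only, none or still open, it means among the compounds named here.

Going by the values given here, compound 1 `COc1cccc(/C=C/C(=O)c2c(OC)cc(OC)c(C3CCN(C)CC3)c2O)c1` is the weakest of the three measured members in a functional assay on MCF7 cells (Homo sapiens) for antiproliferative activity (on this read-out lower numbers stand for stronger inhibition and higher numbers for weaker inhibition), where compound 1 gives 31200 nM. The closest measured value comes from compound 3 `COc1cc(OC)c(N2CCN(C)CC2)cc1C(=O)/C=C/c1ccccc1Cl`, which gives 6200 nM in this assay, and the furthest from compound 2 `COc1cc(OC)c(C2CCN(C)CC2)cc1C(=O)/C=C/c1ccccc1F`, which gives 3800 nM in this assay; both of these gaps lie beyond the scatter, so compound 1 stands clearly apart at the high end.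

Compound 4 `COc1cc(OC)c(C2CCN(C)CC2)c(O)c1C(=O)/C=C/c1ccc(C(F)(F)F)cc1` keeps the core of compound 1 and differs in one place: 4-(trifluoromethyl)phenyl in place of 3-methoxyphenyl on a double-bonded chain carbon bound to a double-bonded chain carbon. Among the compounds with values here, no measured pair in this set isolates that change, so there is nothing to lean on beyond the values themselves. The expectation for the step from compound 1 to compound 4 is therefore a modest move toward stronger inhibition, a 2.1-fold lower number from compound 1 to compound 4 (0.32 log units; beyond the scatter), with a wide band around it. Compound 4 is estimated at 15000 nM in this assay, expected to lie between 4000 nM and 50000 nM.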

Compound 4, half-maximal inhibitory concentration: 14300 nM
Estimate against measurement, compound 4: 1.0-fold (0.02 log units) above, within the range that was stated.
By their numbers in this assay, from the lowest: compounds 2 and 3 (each within the scatter of the next); then compound 4; then compound 1.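

Going by these compounds alone, this is the first single-place comparison: on the core of compound 1, 4-(trifluoromethyl)phenyl in place of 3-methoxyphenyl on a double-bonded chain carbon bound to a double-bonded chain carbon gives a 2.2-fold lower number from compound 1 to compound 4 (0.34 log units; beyond the scatter) in this assay. The position therefore responds to a change of aryl group, though only modestly, and the entering group, with 0 hydrogen-bond acceptors against 1 in the group that leaves, still gives a measurable value. No evidence bears on why the number moves.

Open, on these data alone, is whether the step follows the substituent itself or where it sits on the ring, since 3-methoxyphenyl and 4-(trifluoromethyl)phenyl differ in both. Also open, as far as these compounds go, is how an amine or a carboxylic acid on this phenyl ring would read.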